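A few compounds are considered here, and "the series" means these few. Any claim that something is new, unique, unknown or untested is made for them only; others in the source may bear on it.

Three compounds have been measured so far:

compound 1, `COc1cc(C(=O)N/N=C/c2ccc(F)c(F)c2)cc(OC)c1OC`: 43.7%
compound 2, `COc1ccc(C2OC(c3cc(OC)c(OC)c(OC)c3)=NN2C(C)=O)c(OC)c1`: 92%
compound 3, `COc1cc(/C=N/NC(=O)c2cc(OC)c(OC)c(OC)c2)cc(OC)c1OC`: 48.3%

All three were tested in a functional assay on PC-3 cells (Homo sapiens) for antiproliferative activity, read by MTT assay, tested at 5 uM; a higher number here means a stronger effect of the compound at the concentration tested, a lower number a weaker effect. Among these three numbers compound 1 stands lowest. Compound 3 gives the nearest number, and the gap between compound 1 and compound 3 is within the usual scatter of repeated measurements, so the two cannot be told apart. Compound 2 lies farthest off, with a number beyond the scatter above that of compound 1.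

Compound 4, `COc1cc(C(=O)N/N=C/c2ccccc2F)cc(OC)c1OC`, has not yet been measured in this assay. It differs from compound 1 in one place: 2-fluorophenyl in place of 3,4-difluorophenyl on a carbon with a double bond to nitrogen. Going by the values given here, only that one group changes; the rest of the structure stays as in compound 1.

Among the compounds with values here, no pair of measured compounds differs in exactly this way, so nothing among the measured numbers shows how large such a swap should count. Within the data shown here, with only that one group changing, the expected step of a number 3.7 percentage points lower from compound 1 to compound 4 (within the scatter) is small, not clearly beyond the scatter, and with no strong lean in either direction. Compound 4 is therefore expected to give about 40% in this assay, with a plausible range from 22% to 58%.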

Compound 4, a percentage reported as inhibition, at one concentration (the size of the read-out at that concentration, not a potency): 81.8%
Compound 4: the middle estimate sits 41.8 percentage points below what was measured, outside the stated range (above it).
By their numbers in this assay, from the lowest: compounds 1 and 3 (each within the scatter of the next); then compound 4; then compound 2.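

In this assay, replacing 3,4-difluorophenyl with 2-fluorophenyl on the carbon with a double bond to nitrogen gives a number 38.1 percentage points higher from compound 1 to compound 4 (beyond the scatter), a large step beyond the scatter, while the rest of the structure stays the same. This position is therefore sensitive: a small change in the fluorine pattern of this one ring, with one fluorine fewer and the same ring and no net charge in both groups, is enough to separate a modest read-out from a strong one at the single concentration tested. Going by these compounds alone, the step records only that the two groups differ in effect, and nothing available here explains why the swap has so large an effect.

Since the fluorine count and the fluorine placement change together in this swap, the compounds shown leave open which of the two carries the step. They also leave open how a plain phenyl ring, a chlorine in place of the fluorine, or an amine on the ring would behave at this position, and whether the large step seen here would also hold as a difference in potency rather than in a read-out at one concentration.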